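Swapping the amide cap on a hydroxamic acid antiproliferative

This account rests on a few compounds, and the source may have more. Where it says the series, first, only, none or still open, it means among the compounds named here.

Compound 1 `O=C(CCCCC[C@H](NC(=O)c1ccc(Br)cc1)C(=O)Nc1ccc(-c2ccccc2)cc1)NO`: 307 nM
Compound 2 `CN(C)c1ccc(C(=O)N[C@@H](CCCCCC(=O)NO)C(=O)Nc2cccc3cccnc23)cc1`: 178 nM

Both compounds were tested in a functional assay on HT-29 cells (Homo sapiens) for antiproliferative activity (a higher number here means a weaker inhibitor, a lower number a stronger inhibitor), on colon cancer cells. Compound 1 gives 307 nM in this assay, and compound 2 gives 178 nM. These two numbers sit within the usual scatter of one another, so the data do not separate them.

Compound 3 `O=C(/C=C/c1ccccc1)N[C@@H](CCCCCC(=O)NO)C(=O)Nc1cccc2cccnc12` has not yet been measured. It differs from compound 2 in one place: 2-phenylethenyl in place of 4-(dimethylamino)phenyl on a carbonyl carbon. The rest of the molecule, including the hydroxamic acid end and the shared core, is unchanged.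

Going by the values given here, no measured pair shows what this particular swap does, so there is no step to lean on. Given how close compound 1 and compound 2 lie, a change of the cap appears to matter little here, and compound 3 is expected to stay close to compound 2, with a step of a 1.4-fold higher number from compound 2 to compound 3 (0.15 log units; within the scatter) at most. Compound 3 is therefore estimated at 250 nM, somewhere between 90 nM and 700 nM.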

Compound 3, half-maximal inhibitory concentration: 99 nM
For compound 3 the middle estimate is 2.5-fold (0.40 log units) above the measured one; the range from low to high includes it.
By their numbers in this assay, from the lowest: compounds 3, 2 and 1 (each within the scatter of the next, the first and the last beyond it).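

Going by these compounds alone, this is the first direct comparison at this position, the group on a carbonyl carbon whose other neighbour is an amide-type nitrogen. In this assay, putting 2-phenylethenyl in place of 4-(dimethylamino)phenyl gives a 1.8-fold lower number from compound 2 to compound 3 (0.25 log units; within the scatter), so the data do not separate the two compounds. The swap removes the nitrogen and its hydrogen-bond acceptor and adds a double bond outside the aromatic ring, yet the two values stay within the scatter, and nothing available here explains this result.

Still open, going by these compounds, is what a 2-phenylethyl group, which has a saturated chain, a plain phenyl group or a carboxylic acid would give at this position. On these data alone, it is also open whether this swap would read the same way on the core of compound 1.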